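This account rests on a few compounds, and the source may have more. Where it says the series, first, only, none or still open, it means among the compounds named here.

Measured compounds: compound 1 `Nc1ccccc1NC(=O)c1ccc(CSc2ccc(Br)cc2)cc1`, compound 2 `Cc1cc(C)cc(SCc2ccc(/C=C/C(=O)Nc3ccccc3N)cc2)c1`, compound 3 `Nc1ccccc1NC(=O)c1ccc(CSCCc2ccccc2)cc1`.

In a functional assay on A549 cells (Homo sapiens) for inhibition, read by CCK-8 assay, with a stated time of 72 h, tested at 2 uM (a lower number here means less inhibition of growth, a higher number more inhibition of growth at the concentration tested), compound 1 gives 33.2%, compound 2 gives 46.1% and compound 3 gives 44.9%. Compound 2 holds the highest number of the three, and compound 3 sits within the scatter of it, while compound 1 lies beyond the scatter below it. Within the data shown here, the only measured step, a number 11.7 percentage points higher from compound 1 to compound 3 (beyond the scatter), changes the group on the sulfur as well. Compound 4 `CCc1ccc(SCc2ccc(/C=C/C(=O)Nc3ccccc3N)cc2)cc1` differs from compound 2 by 4-ethylphenyl in place of 3,5-dimethylphenyl on a sulfur. Both groups are plain alkyl-bearing phenyl rings, so the measured step gives little guidance, and a step no larger than the scatter is expected in this assay: a number 1.1 percentage points lower from compound 2 to compound 4 (within the scatter). Compound 4 is therefore estimated at 45%, in a range from 33% to 57%.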

Compound 4, percent growth inhibition at one concentration: 60.7%
The estimate for compound 4 lay 15.7 percentage points below the measured number; the whole stated range lies below it.
By their numbers in this assay, from the lowest: compound 1; then compounds 3 and 2 (each within the scatter of the next); then compound 4.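

In this assay, the aryl group on the sulfur proves sensitive to how its carbons are arranged: 4-ethylphenyl in place of 3,5-dimethylphenyl gives a number 14.6 percentage points higher from compound 2 to compound 4 (beyond the scatter) on the shared core. The two groups match in heavy atoms, aromatic rings and hydrogen-bond donors and acceptors, so these counts do not separate compound 2 from compound 4. Nothing measured here explains the step.

As far as these compounds go, it remains open whether a 4-methylphenyl, 4-propylphenyl or 4-methoxyphenyl group on the sulfur would give a similar number, and whether 4-ethylphenyl would give a similar step on the core of compound 1.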